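Swapping the aryl ring of a prenylated chalcone

The source may hold more compounds than are shown below. What is called first, only, known or untested is meant among the compounds shown, and "the series" means these compounds.

In an ADME assay on MCF7-DOX cells (Homo sapiens) for cytotoxicity, read by MTT assay, with a stated time of 48 h (on this read-out lower numbers stand for stronger inhibition and higher numbers for weaker inhibition), three chalcones have been measured. Compound 1 `COc1cccc(/C=C/C(=O)c2c(OC)cc(OC)c(CC=C(C)C)c2O)c1` gives 49200 nM and stands lowest of the three numbers, although its gap to compound 3, which gives 95000 nM, and to compound 2, which gives 99200 nM, lies within the scatter in both cases, so no order among them can be read from the data. Compound 2 `COc1cc(O)c(C(=O)/C=C/c2cccc(N3CCNCC3)c2)c(OC)c1` and compound 3 `COc1ccc(C(=O)/C=C/c2cccc(N3CCNCC3)c2)c(OC)c1` differ only in a hydroxy on the shared core, and the step of a 1.0-fold lower number from compound 2 to compound 3 (0.02 log units; within the scatter) is within the scatter. Compound 4 `COc1cc(OC)c(C(=O)/C=C/c2ccc(F)cc2)c(O)c1CC=C(C)C` is the next compound to be measured in this assay. It departs from compound 1 in one place: 4-fluorophenyl in place of 3-methoxyphenyl on a double-bonded chain carbon bound to a double-bonded chain carbon. Among the measured compounds shown here, none of the measured steps touches the aryl ring on the double-bonded chain carbon, so nothing in the data bears directly on this change, and the one measured step concerns a different part of the molecule and was itself within the scatter. On that basis the step of a 1.1-fold lower number from compound 1 to compound 4 (0.04 log units; within the scatter) is expected to be no larger than the scatter. Compound 4 is therefore estimated at 45000 nM in this assay, with a range from 15000 nM to 150000 nM.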

Compound 4, half-maximal inhibitory concentration: 53700 nM
Compound 4: middle estimate off by 1.2-fold (0.08 log units), on the low side; low and high end bracket the measured number.
By their numbers in this assay, from the lowest: compounds 1, 4, 3 and 2 (each within the scatter of the next).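

Among the compounds shown here, the step of a 1.1-fold higher number from compound 1 to compound 4 (0.04 log units; within the scatter) is the first measured change on a double-bonded chain carbon bound to a double-bonded chain carbon, and in this assay it lies within the scatter. For this one pair, then, 4-fluorophenyl can take the place of 3-methoxyphenyl on the prenylated core without a readable change in the number, even though the methoxy oxygen and its hydrogen-bond acceptor leave and a fluorine enters. No measurement of any property of these two groups is available to account for this result.

As far as these compounds go, what stays open is whether any group at this place can move the number beyond the scatter, for instance a phenyl ring carrying a carboxylic acid or an amine in place of 4-fluorophenyl. Both steps shown so far lie within the scatter, so neither this position nor the hydroxy change on the shared core has yet given a difference that could guide a comparison.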